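The source may report more compounds than this note shows. Statements on the series, on what has been measured and on what is new or still open speak of the compounds shown alone.

Measured so far in a functional assay for inhibition, with Homo sapiens as the target; a lower number here means tighter binding, a higher number weaker binding:
- compound 1, `O=C(O)CC/C=C\CC1COC(c2ccc([N+](=O)[O-])cc2)OC1c1cccnc1`: 933 nM
- compound 2, `O=C(O)CC/C=C\CC1COC(c2ccco2)OC1c1cccnc1`: 1260 nM
- compound 3, `CC(C)(C)c1ccc(OC(C)(C)C2OCC(C/C=C\CCC(=O)O)C(c3cccnc3)O2)cc1`: 1910 nM

Compound 3 gives the largest of the three numbers; its gap to compound 2 lies within the scatter, and only its gap to compound 1 lies beyond it. Compound 4, `COc1ccc(OC(C)(C)C2OCC(C/C=C\CCC(=O)O)C(c3cccnc3)O2)c([N+](=O)[O-])c1`, has not yet been measured in this assay. It differs from compound 3 in one place: 4-methoxy-2-nitrophenyl in place of 4-(tert-butyl)phenyl on an oxygen on a saturated carbon.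

Among the compounds with values here, only one measured step exists, a 1.4-fold higher number from compound 1 to compound 2 (0.13 log units; within the scatter), and it concerns an aryl exchange on a saturated ring carbon, not on the oxygen where compound 4 changes. It is within the scatter. Within the data shown here, no measured pair touches the aryl group on that oxygen, so nothing bears directly on the change from compound 3 to compound 4; the one aryl swap seen was small. For compound 4 no step beyond the scatter is therefore expected, a 1.1-fold lower number from compound 3 to compound 4 (0.05 log units; within the scatter), with a wide range. In this assay compound 4 is estimated at 1700 nM, between 600 nM and 5000 nM.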

Compound 4, dissociation constant: 6.17 nM
Estimate against measurement, compound 4: 280-fold (2.44 log units) above; measured number below the stated range.
By their numbers in this assay, from the lowest: compound 4; then compounds 1, 2 and 3 (each within the scatter of the next, the first and the last beyond it).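

In this assay, within the data shown here, the aryl group on an oxygen on a saturated carbon turns out to be a place of large effect: 4-methoxy-2-nitrophenyl in place of 4-(tert-butyl)phenyl gives a far lower number (a 310-fold lower number from compound 3 to compound 4 (2.49 log units; beyond the scatter)), while the only earlier step (a 1.4-fold higher number from compound 1 to compound 2 (0.13 log units; within the scatter)) concerned another place and lay within the scatter. The series therefore does not respond evenly to aryl exchange, and the entering group brings hydrogen-bond acceptors that the leaving group lacks. No measurement available here explains the size of this step.

As far as these compounds go, the nitro and methoxy groups enter together, so their separate contributions remain open. Also open, from the compounds shown here alone, is whether an amine or a nitrile in place of the nitro group, or an unsubstituted phenyl, would keep the number this low.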